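Compound 2 and the step to its fluoro analogue

The source may hold more compounds than are shown below. What is called first, only, known or untested is meant among the compounds shown, and "the series" means these compounds.

Values from a functional assay on A549 cells (Homo sapiens) for antiproliferative activity, read by MTT assay, with a stated time of 48 h (on this read-out higher numbers stand for weaker inhibition and lower numbers for stronger inhibition), are as follows:
- compound 1 `Clc1ccc2[nH]c(-c3cn(-c4ccccc4)nc3-c3ccccc3)nc2c1` gives 2370 nM
- compound 2 `Brc1ccc2[nH]c(-c3cn(-c4ccccc4)nc3-c3ccccc3)nc2c1` gives 1810 nM
- compound 3 `COc1ccc2[nH]c(-c3cn(-c4ccccc4)nc3-c3ccccc3)nc2c1` gives 1230 nM

Compound 2 is not separated from compound 1 or compound 3, since its value lies within the scatter of both. Compound 4 `Fc1ccc(-c2nn(-c3ccccc3)cc2-c2nc3cc(Br)ccc3[nH]2)cc1` has fluoro in place of hydrogen on an aromatic carbon, a change of phenyl to 4-fluorophenyl, counted as fluoro in place of hydrogen on an aromatic carbon against compound 2. The nearest guides are a 1.3-fold lower number from compound 1 to compound 2 (0.12 log units; within the scatter) together with a 1.5-fold lower number from compound 2 to compound 3 (0.17 log units; within the scatter) and a 1.9-fold lower number from compound 1 to compound 3 (0.28 log units; within the scatter) and all three swap the group that is bromo in compound 2 and compound 4. Within the data shown here, none of them touches the phenyl that changes, and no measured compound carries fluoro, so they bear on this step only indirectly. No shift beyond the scatter is expected. The expected step is a 1.2-fold lower number from compound 2 to compound 4 (0.08 log units; within the scatter) and this remains an estimate. In this assay compound 4 is estimated at 1500 nM within an expected range of 600 nM up to 3500 nM for now.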

Compound 4, half-maximal inhibitory concentration: 5830 nM
Beside the measured number, compound 4's estimate is 3.9-fold (0.59 log units) below it, outside the stated range (above it).
By their numbers in this assay, from the lowest: compounds 3, 2 and 1 (each within the scatter of the next); then compound 4.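

In this assay, among these compounds, the change of phenyl to 4-fluorophenyl gives a 3.2-fold higher number from compound 2 to compound 4 (0.51 log units; beyond the scatter), the only step so far that lies beyond the scatter. Among the compounds shown here, the three swaps at the bromo position all stayed within the scatter, so this phenyl is the first place where a single change separates two compounds, and here fluoro in place of hydrogen, para to a large group, weakens inhibition modestly. No measurement at hand explains this shift.

On these data alone, it remains open whether the same step holds with chloro or methoxy in place of bromo, as in compound 1 and compound 3. Also open, as far as these compounds go, is whether an amine or a carboxylic acid at this place on the phenyl would move the number in the same direction as fluoro.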